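Shrinking the Ring on the Aromatic Nitrogen

The source may hold more compounds than are shown below. What is called first, only, known or untested is meant among the compounds shown, and "the series" means these compounds.

Three measured compounds share one phosphorylated core and differ only in the group on one aromatic carbon. Compound 1 `COc1ncnc2c1ncn2C1O[C@H](CO)[C@H](O[C@@H]2OC(CO)[C@H](OP(=O)(O)O)C(OP(=O)(O)O)[C@@H]2O)[C@@H]1OP(=O)(O)O` gives 0.57 nM in a functional assay (Hepatocyte) with Rattus norvegicus as the target; a higher number here means that more compound is needed for the effect, a lower number that less compound is needed. Compound 2 `Nc1ncnc2c1ncn2C1O[C@H](CO)[C@H](O[C@@H]2OC(CO)[C@H](OP(=O)(O)O)C(OP(=O)(O)O)[C@@H]2O)[C@@H]1OP(=O)(O)O` gives 1 nM in this assay, and the step of a 1.8-fold higher number from compound 1 to compound 2 (0.24 log units; within the scatter). For the measured compounds named here, compound 3 `O=P(O)(O)OC1[C@@H](OP(=O)(O)O)C(CO)O[C@@H](O[C@@H]2[C@H](OP(=O)(O)O)C(n3cnc4c(NC5CCCCC5)ncnc43)O[C@@H]2CO)[C@H]1O` gives 0.56 nM in this assay; this is the lowest of the three numbers, yet no step sets it apart, since a 1.0-fold lower number from compound 1 to compound 3 (0.01 log units; within the scatter) and a 1.8-fold lower number from compound 2 to compound 3 (0.25 log units; within the scatter).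

Compound 4 `O=P(O)(O)OC1[C@@H](OP(=O)(O)O)C(CO)O[C@@H](O[C@@H]2[C@H](OP(=O)(O)O)C(n3cnc4c(NC5CCCC5)ncnc43)O[C@@H]2CO)[C@H]1O` has not yet been measured. cyclopentyl in place of cyclohexyl on a nitrogen on an aromatic ring The most relevant precedent is the step that introduced the cyclohexyl itself, a 1.8-fold lower number from compound 2 to compound 3 (0.25 log units; within the scatter), which stayed within the scatter even though it exchanged hydrogen for a whole ring. The exchange of methoxy for cyclohexylamino, a 1.0-fold lower number from compound 1 to compound 3 (0.01 log units; within the scatter), likewise moved nothing beyond the scatter. With every group tried at this position giving numbers within the scatter of one another, the analysis expects the change from cyclohexyl to cyclopentyl to produce no step beyond the scatter, and the expected step is a 1.1-fold higher number from compound 3 to compound 4 (0.03 log units; within the scatter). Compound 4 is therefore estimated at 0.6 nM in this assay, with an expected range from 0.3 nM to 1.2 nM.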

Compound 4, half-maximal effective concentration: 0.77 nM
Estimate against measurement, compound 4: 1.3-fold (0.11 log units) below; measured number inside the range.
By their numbers in this assay, from the lowest: compounds 3, 1, 4 and 2 (each within the scatter of the next).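

In this assay, cyclopentyl takes the place of cyclohexyl on the nitrogen with a 1.4-fold higher number from compound 3 to compound 4 (0.14 log units; within the scatter), so the tolerance seen so far at this position now extends to a five-membered ring as well as a six-membered one. Compared with the groups that carry no ring, the cyclopentylamino compound shows a 1.3-fold lower number from compound 2 to compound 4 (0.11 log units; within the scatter) against amino and a 1.4-fold higher number from compound 1 to compound 4 (0.13 log units; within the scatter) against methoxy, which places all four groups on this aromatic carbon within the scatter of one another, with no compound shown going against that. The data offered here give no explanation for this uniform result.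

What the compounds shown leave open is where this tolerance ends, since no group here produces a step beyond the scatter and so none marks a limit at this position. A smaller ring such as cyclopropyl, an aromatic ring such as phenyl or a longer chain ending in a carboxylic acid on the same nitrogen would test whether the numbers stay this close together.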